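This account rests on a few compounds, and the source may have more. Where it says the series, first, only, none or still open, it means among the compounds named here.

Of the compounds shown here, three that share one core have so far been measured in an assay on SH-EP1 cells for agonist activity at Neuronal acetylcholine receptor; alpha4/beta2 (Homo sapiens), read by FLIPR and calcium flux; on this read-out lower numbers stand for an effect already at smaller amounts and higher numbers for an effect only at larger amounts of compound. Compound 1 `CC(=O)N1CC2CC(C1)N2` gives 9700 nM, compound 2 `CCCC(=O)N1CC2CC(C1)N2` gives 850 nM, and compound 3 `CC(C)C(=O)N1CC2CC(C1)N2` gives 20000 nM, the highest of the three numbers. Compound 4 `O=C(C1CCC1)N1CC2CC(C1)N2` has not been measured; it differs from compound 3 by cyclobutyl in place of isopropyl on a carbonyl carbon. Among the compounds with values here, two measured steps bear on this change, both involving the isopropyl group: a 2.1-fold higher number from compound 1 to compound 3 (0.31 log units; beyond the scatter) and a 24-fold higher number from compound 2 to compound 3 (1.37 log units; beyond the scatter). Cyclobutyl resembles isopropyl more than the propyl chain of compound 2, so only a modest step is expected, most likely downward. For compound 4 the number in this assay is expected to be 6000 nM, with a range from 1500 nM to 25000 nM. That estimate corresponds to a 3.3-fold lower number from compound 3 to compound 4 (0.52 log units; beyond the scatter).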

Compound 4, half-maximal effective concentration: 11000 nM
Compound 4: the middle estimate sits 1.8-fold (0.26 log units) below what was measured; low and high end bracket the measured number.
By their numbers in this assay, from the lowest: compound 2; then compounds 1, 4 and 3 (each within the scatter of the next, the first and the last beyond it).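

In this assay cyclobutyl on the carbonyl carbon cannot be told apart from isopropyl (a 1.8-fold lower number from compound 3 to compound 4 (0.26 log units; within the scatter)) or from methyl (a 1.1-fold higher number from compound 1 to compound 4 (0.05 log units; within the scatter)); both steps lie within the scatter. The ring does not reproduce what the propyl chain gives (a 13-fold higher number from compound 2 to compound 4 (1.11 log units; beyond the scatter)), so among these four compounds only the propyl chain stands apart from all the others. Nothing measured here explains that difference.

Still open, as far as these compounds go, is whether a butyl or longer chain would give a lower number than propyl. Also open, from the compounds shown here alone, is whether cyclopropyl, or a chain carrying an amine, would side with propyl or with cyclobutyl.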